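Two Amine Substituents on a Shared Core, One Swapped

The source may report more compounds than this note shows. Statements on the series, on what has been measured and on what is new or still open speak of the compounds shown alone.

Both compounds here share the same core, and differ only in the two groups carried on a single amine nitrogen. Compound 1, `Cc1cc(=O)c2ccc(O)c(CN(Cc3ccccc3)Cc3ccccc3)c2o1`, was tested in a functional assay on SK-OV-3 cells (Homo sapiens) for inhibition, read by sulforhodamine B assay, with a stated time of 72 h (a lower number here means a stronger inhibitor, a higher number a weaker inhibitor), where compound 1 gives 19 ug/mL. Among the compounds with values here, compound 2, `CCN(Cc1ccc(OC)cc1)Cc1c(O)ccc2c(=O)cc(C)oc12`, gives 57.5 ug/mL in this assay, the higher of the two numbers so far, and its gap from compound 1 lies beyond the usual scatter of repeated measurements.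

Compound 3, `COc1ccc(CN(Cc2ccc3ccccc3c2)Cc2c(O)ccc3c(=O)cc(C)oc23)cc1`, has not yet been measured. It differs from compound 2 in one place: naphthalen-2-yl in place of methyl on a saturated chain carbon bound to an amine nitrogen. In plain terms, a small group on the amine is replaced by a much larger aromatic one, and the larger-substituted amine of compound 1 is the one that gave the lower number.

On that basis the number for compound 3 is expected to move downward, because compound 1 gives 19 ug/mL in this assay. The step from compound 2 is estimated as a 2.3-fold lower number from compound 2 to compound 3 (0.36 log units; beyond the scatter). Compound 3 is therefore expected to give about 25 ug/mL, with a likely range from 10 ug/mL to 60 ug/mL.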

Compound 3, half-maximal inhibitory concentration: > 100 ug/mL
Compound 3: no number, only a limit; the forecaster's own chance of this, stated with the estimate: 5%; at least 4.0-fold (0.60 log units) between middle value and limit.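

Compound 3 reads > 100 ug/mL in this assay, and this is a limit of the assay, not a number. Replacing methyl with naphthalen-2-yl on a saturated chain carbon bound to an amine nitrogen, which can also be read as ethyl to (naphthalen-2-yl)methyl, gives an at least 1.7-fold higher number from compound 2 to compound 3 (0.24 log units; that floor lies within the scatter). This large aromatic group therefore brought no lower number at this position, although the floor of the step alone does not separate the pair beyond the scatter, and the reading of this change rests on a single assay limit: the limit of > 100 ug/mL in this assay, at which 1 of the 3 values shown sits.

As far as these compounds go, how far the true value of compound 3 lies past its limit stays open, so the real size of the step is unknown. Also open, from the compounds shown here alone, is how this position would respond to a group of intermediate size or different character in place of naphthalen-2-yl, such as a propyl chain, a cyclohexyl ring or a pyridin-3-yl ring.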